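The source may hold more compounds than are shown below. What is called first, only, known or untested is meant among the compounds shown, and "the series" means these compounds.

Among the measured compounds shown here, compound 1, with the structure `Cc1cc(Cl)ccc1C(=O)Nc1ccc(S(=O)(=O)Nc2ccccc2)cc1`, is the only compound here that gives an actual number in a functional assay on HEK293 cells for agonist activity at probable G-protein coupled receptor 27 (Homo sapiens), read by a luciferase reporter and beta-arrestin recruitment, with a stated time of 10 min; a lower number here means that less compound is needed, a higher number that more compound is needed for the effect: compound 1 gives 912 nM. Compound 2, with the structure `O=C(Nc1ccc(Cl)cc1Cl)c1ccc(S(=O)(=O)Nc2ccccc2)cc1`, is different. In this assay compound 2 gives > 100000 nM, which is a limit of the assay rather than a number. For the measured compounds named here, that is the situation described by the limit of > 100000 nM in this assay, at which 1 of the 2 values shown sits, so the two measured compounds share no step that would show how a single change moves the read-out.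

Compound 3, with the structure `O=C(Nc1ccc(S(=O)(=O)Nc2ccccc2)cc1)c1ccc(Cl)cc1F`, is not yet measured. It differs from compound 1 by fluoro in place of methyl on an aromatic carbon, a fluoro in place of methyl on an aromatic carbon. Going by the values given here, no measured pair in this set reflects that kind of swap, so the step of a 1.6-fold higher number from compound 1 to compound 3 (0.22 log units; within the scatter) is expected to be small, most likely a modest weakening that may not exceed the usual scatter. Compound 3 is therefore estimated at 1500 nM in this assay, within the range 400 nM to 6000 nM.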

Compound 3, half-maximal effective concentration: 3980 nM
For compound 3 the middle estimate is 2.7-fold (0.42 log units) below the measured one, within the range that was stated.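

In this assay, among the compounds shown here, the first single change that can be read is this one: a 4.4-fold higher number from compound 1 to compound 3 (0.64 log units; beyond the scatter). At this place on the ring, methyl and fluoro are therefore not interchangeable, even though each is a single heavy atom with no hydrogen-bond donors or acceptors, yet the change is modest and compound 3 still gives a real number rather than a limit. Nothing shown here explains why this swap moves the read-out.

The compounds shown leave open how hydrogen, methoxy or a longer chain such as ethyl would read at this same place, so the preferred group there remains unknown. They also leave open whether fluoro in place of methyl would give a similar step at another position on this ring.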